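Trifluoromethyl to Methylsulfonyl on a Shared Core

A few compounds are considered here, and "the series" means these few. Any claim that something is new, unique, unknown or untested is made for them only; others in the source may bear on it.

Compound 3 (`FC(F)(F)c1nc2cc(Cl)c(Cl)cc2n1C1CCCC1`) stands in the middle of the three measured compounds in a functional assay on HCT-116 cells (Homo sapiens) for cytotoxicity, read by MTT assay, with a stated time of 48 h (on this read-out lower numbers stand for stronger inhibition of growth and higher numbers for weaker inhibition of growth), at 22000 nM with compound 2 (`FC(F)(F)c1nc2cc(Cl)c(Cl)cc2n1Cc1ccccc1`) lower at 8600 nM and compound 1 (`FC(F)(F)c1nc2cc(Cl)c(Cl)cc2n1CC1CC1`) higher at 61300 nM in that read-out. Compound 4 (`CS(=O)(=O)c1nc2cc(Cl)c(Cl)cc2n1C1CCCC1`) has methylsulfonyl in place of trifluoromethyl on an aromatic carbon. The measured steps are a 7.1-fold lower number from compound 1 to compound 2 (0.85 log units; beyond the scatter) and a 2.8-fold lower number from compound 1 to compound 3 (0.45 log units; beyond the scatter) and a 2.6-fold higher number from compound 2 to compound 3 (0.41 log units; beyond the scatter) and each is modest. All three change only the group on an aromatic nitrogen, so they suggest a size but no direction. In this assay the expected change, leaning only slightly higher and not clearly beyond the scatter, is a 1.8-fold higher number from compound 3 to compound 4 (0.26 log units; within the scatter) by estimate. Compound 4 is estimated at 40000 nM (expected range 12000 nM to 120000 nM) .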

Compound 4, concentration for 50% growth inhibition: 600 nM
Beside the measured number, compound 4's estimate is 67-fold (1.82 log units) above it, and the stated range ends above it.
By their numbers in this assay, from the lowest: compound 4; then compound 2; then compound 3; then compound 1.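

In this assay, among the compounds shown here, the group on the aromatic carbon between two ring nitrogen atoms turns out to matter far more than the group on the aromatic nitrogen: a 37-fold lower number from compound 3 to compound 4 (1.56 log units; beyond the scatter) is large, whereas the earlier steps were all modest. The two groups have the same count of heavy atoms, but methylsulfonyl brings hydrogen-bond acceptors that trifluoromethyl lacks. Nothing available explains the step.

The compounds shown leave open whether methylsulfonyl gives a similar step with the benzyl of compound 2 on the aromatic nitrogen. They also leave open how an amine or a carboxylic acid would fare on this carbon.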